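Tolerance check for the aryl swap at compound 4

The source may hold more compounds than are shown below. What is called first, only, known or untested is meant among the compounds shown, and "the series" means these compounds.

For the measured compounds named here, compound 1 `COc1ccc(CN(Cc2ccc(C(C)(C)C)cc2)Cc2cc3cc(C)ccc3[nH]c2=O)cc1` is the starting point of the three measured members. In a toxicity assay on MDCK cells (Canis lupus familiaris) for cytotoxicity, read by crystal violet staining, with a stated time of 48 h (a higher number here means that more compound is tolerated, a lower number that less compound is tolerated), compound 1 gives > 10000 nM, which is a limit of the assay and not a number. Compound 2 `Cc1ccc2[nH]c(=O)c(CN(Cc3ccc(C(N)=O)cc3)Cc3ccc(C(C)(C)C)cc3)cc2c1` gives > 5000 nM in this assay, again only a limit. Compound 3 `COc1ccc(C(C)N(Cc2ccc(C(C)(C)C)cc2)Cc2cc3cc(C)ccc3[nH]c2=O)cc1` gives > 5000 nM, likewise a limit. Compound 3 therefore stands at a limit, and the two further values shown are limits as well, so no order among the three can be read.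

The measured steps are a step that the two limits leave unreadable from compound 1 to compound 2, a step that the two limits leave unreadable from compound 1 to compound 3 and a step that the two limits leave unreadable from compound 2 to compound 3. All three remain unreadable; the values sit at the limit of > 10000 nM in this assay, at which 1 of the 3 values shown sits, and at the limit of > 5000 nM in this assay, at which 2 of the 3 values shown sit.

Compound 4 `Cc1ccc2[nH]c(=O)c(CN(Cc3ccc(C(C)(C)C)cc3)C(C)c3ccc(N(C)C)c(Cl)c3)cc2c1` differs from compound 3 by 3-chloro-4-(dimethylamino)phenyl in place of 4-methoxyphenyl on a saturated chain carbon bound to an amine nitrogen and a saturated chain carbon. Going by the values given here, two measured steps touch the same saturated chain carbon bound to an amine nitrogen, namely a step that the two limits leave unreadable from compound 1 to compound 3 and a step that the two limits leave unreadable from compound 2 to compound 3; both are unreadable, so no size of step in this assay can be taken from them. No step beyond the scatter is expected in this assay; the expected step is a step that the limit leaves unreadable from compound 3 to compound 4. Compound 4 is expected to give 8000 nM in this assay, within 2500 nM to 20000 nM, most probably reported again only as a limit.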

Compound 4, half-maximal cytotoxic concentration: 9800 nM
Beside the measured number, compound 4's estimate is 1.2-fold (0.09 log units) below it; low and high end bracket the measured number.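

With 3-chloro-4-(dimethylamino)phenyl in place of 4-methoxyphenyl on a saturated chain carbon bound to an amine nitrogen and a saturated chain carbon, in this assay compound 4 gives 9800 nM, the only value among the compounds shown that is a number and not a limit. The one step that can be read is an at least 1.0-fold lower number from compound 1 to compound 4 (0.00 log units; that floor lies within the scatter), so no real loss of tolerance can be claimed for this change, and that step rests on a limit: the limit of > 10000 nM in this assay, at which 1 of the 4 values shown sits.

The steps from compound 2 and from compound 3 to compound 4 cannot be read, as those two compounds also stand at a limit: the limit of > 5000 nM in this assay, at which 2 of the 4 values shown sit.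

The compounds shown do not separate the chlorine from the dimethylamino group, which a 3-chlorophenyl or a 4-(dimethylamino)phenyl alone on this carbon would do. Also open, going by these compounds, is whether a carboxylic acid or a morpholine on this aromatic ring would stay in the same range in this assay, and whether any change at this position gives a step beyond the scatter.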